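A Second Fluoro on a Compound Without a Number

This account rests on a few compounds, and the source may have more. Where it says the series, first, only, none or still open, it means among the compounds named here.

In an ADME assay on Vero cells (Chlorocebus sabaeus) for cytotoxicity, read by MTT assay, with a stated time of 72 h (on this read-out higher numbers stand for an effect only at larger amounts of compound and lower numbers for an effect already at smaller amounts), compound 1 (`CC(=O)c1ccccc1C(=O)Nc1nc(-c2ccccn2)cs1`) gives 86700 nM while compound 3 (`O=C(Nc1nc(-c2ccccn2)cs1)c1cc(F)ccc1F`) gives 3300 nM on the same read-out. Compound 2 (`O=C(Nc1nc(-c2ccccn2)cs1)c1ccccc1F`) has no single number there, its entry reading ("not determined" (no result reported)), so it cannot be placed among them. Compound 4 (`O=C(Nc1nc(-c2ccccn2)cs1)c1c(F)cccc1F`) has yet to be measured. The change fluoro in place of hydrogen on an aromatic carbon is fluoro in place of hydrogen on an aromatic carbon, ortho to a large group and meta to a fluoro group. For the measured compounds named here, no measured step anchors this change. Going by the values given here, a step beyond the usual scatter is not expected in either direction, so the expectation rests on the span from compound 3 at 3300 nM to compound 1 at 86700 nM as the only guide. Compound 4 is estimated in this assay at 15000 nM (2500 nM to 90000 nM).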

Compound 4, half-maximal effective concentration: 3200 nM
Estimate against measurement, compound 4: 4.7-fold (0.67 log units) above; the range from low to high includes it.
By their numbers in this assay, from the lowest: compounds 4 and 3 (each within the scatter of the next); then compound 1.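

For the compounds shown here, compound 2 has no single number in this assay so no step from it to compound 4 can be read. The compounds shown leave open what fluoro in place of hydrogen does on its own at this place. No evidence on this result is available.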